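Pyridyl isomer swap on the guanidine series

The compounds below may be only part of what the source reports. "The series", "measured", "known", "first", "only" and "open" are said of these compounds alone.

Compound 1 `N=C(NCCCc1c[nH]cn1)NCCC(c1ccc(F)cc1)c1ccccn1` stands lowest of the two numbers in a functional assay on ileum for antagonist activity at histamine H1 receptor (Cavia porcellus) (a lower number here means tighter binding, a higher number weaker binding), giving 22.4 nM. Compound 2 `N=C(NCCCc1c[nH]cn1)NCCC(c1ccc(C(F)(F)F)cc1)c1ccccn1` gives 282 nM in this assay; the step is a 13-fold higher number from compound 1 to compound 2 (1.10 log units; beyond the scatter), a change of trifluoromethyl in place of fluoro on an aromatic carbon. Compound 3 `N=C(NCCCc1c[nH]cn1)NCCC(c1ccc(F)cc1)c1cccnc1` awaits measurement. It differs from compound 1 by pyridin-3-yl in place of pyridin-2-yl on a saturated chain carbon bound to an aromatic carbon and a saturated chain carbon. Among the measured compounds shown here, the single measured step concerns a substituent on an aromatic carbon elsewhere and leaves the pyridyl group untouched, so no measured step bears on this change; how much the position of the ring nitrogen matters is unknown here. With nothing to anchor the direction, the expectation for compound 3 is a number close to that of compound 1, with the step of a 2.2-fold higher number from compound 1 to compound 3 (0.35 log units; beyond the scatter) estimated as small but with wide uncertainty on either side. Compound 3 is therefore expected at 50 nM, in the range 10 nM to 400 nM.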

Compound 3, dissociation constant: 195 nM
Compound 3: the middle estimate sits 3.9-fold (0.59 log units) below what was measured; low and high end bracket the measured number.
By their numbers in this assay, from the lowest: compound 1; then compounds 3 and 2 (each within the scatter of the next).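

In this assay, the position of the ring nitrogen on this saturated chain carbon is not a silent change: an 8.7-fold higher number from compound 1 to compound 3 (0.94 log units; beyond the scatter). Pyridin-2-yl and pyridin-3-yl have the same heavy atoms and the same hydrogen-bond donor and acceptor counts, so this step comes from a difference in how the same atoms are joined, and it shows that this position responds to more than the fluoro and trifluoromethyl change on the aromatic carbon elsewhere. Nothing available here accounts for the size or direction of this step.

Open, on these data alone, is whether pyridin-4-yl or a plain phenyl on the same carbon would stand nearer compound 1 or compound 3 in this assay. Also open, as far as these compounds go, is whether trifluoromethyl in place of fluoro on the pyridin-3-yl compound would repeat a 13-fold higher number from compound 1 to compound 2 (1.10 log units; beyond the scatter).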